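Amide aryl variation on the shared core, MDA-MB-231 proliferation

The compounds below may be only part of what the source reports. "The series", "measured", "known", "first", "only" and "open" are said of these compounds alone.

Compounds measured so far:
compound 1 `O=C(Nc1cccc(-c2oc3cc(-c4ccc(F)cc4)ccc3c(=O)c2O)c1)c1ccccc1F` with 7240 nM
compound 2 `O=C(Nc1cccc(-c2oc3cc(-c4ccc(F)cc4)ccc3c(=O)c2O)c1)c1ccc(Br)cc1` with 24900 nM
compound 3 `O=C(Nc1cccc(-c2oc3cc(-c4ccc(F)cc4)ccc3c(=O)c2O)c1)c1ccc(Cl)nc1` with 1760 nM

All three share the core and differ only in the aryl group on the amide carbonyl. In a functional assay on MDA-MB-231 cells (Homo sapiens) for antiproliferative activity, read by CCK-8 assay, with a stated time of 72 h (a higher number here means a weaker inhibitor, a lower number a stronger inhibitor), compound 3 gives the lowest number of the three; the nearest is compound 1, the furthest compound 2. The steps read a 4.1-fold lower number from compound 1 to compound 3 (0.61 log units; beyond the scatter) and a 14-fold lower number from compound 2 to compound 3 (1.15 log units; beyond the scatter), so compound 3 stands apart from both by more than the scatter. The step of a 3.4-fold higher number from compound 1 to compound 2 (0.54 log units; beyond the scatter) shows that a six-membered carbon-only ring carrying a substituent at the position named in the group 4-bromophenyl gave the highest number in the series.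

Compound 4 `N#Cc1ccc(C(=O)Nc2cccc(-c3oc4cc(-c5ccc(F)cc5)ccc4c(=O)c3O)c2)cc1` is not yet measured. The change from compound 3 is 4-cyanophenyl in place of 6-chloropyridin-3-yl on a carbonyl carbon. Within the data shown here, no measured pair covers exactly this exchange; the step of a 14-fold lower number from compound 2 to compound 3 (1.15 log units; beyond the scatter) is the closest, since it also trades a carbon-only ring for the 6-chloropyridin-3-yl group, and it was large. Compound 4 keeps a carbon-only ring, as compound 2 does, but with a nitrile in place of bromine; compound 4 is therefore expected to show a weaker result than compound 3, with the step of a 2.6-fold higher number from compound 3 to compound 4 (0.41 log units; beyond the scatter). The estimate for compound 4 is 4500 nM, within 1500 nM to 13000 nM.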

Compound 4, half-maximal inhibitory concentration: 11600 nM
Beside the measured number, compound 4's estimate is 2.6-fold (0.41 log units) below it; measured number inside the range.
By their numbers in this assay, from the lowest: compound 3; then compounds 1 and 4 (each within the scatter of the next); then compound 2.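

In this assay, 4-cyanophenyl does not reproduce the low number of the 6-chloropyridin-3-yl group, with a 6.6-fold higher number from compound 3 to compound 4 (0.82 log units; beyond the scatter), so compound 3 remains lower than all three compounds carrying a carbon-only ring. Among those rings the nitrile brings a modest change from the bromide, with a 2.1-fold lower number from compound 2 to compound 4 (0.33 log units; beyond the scatter), whereas a 1.6-fold higher number from compound 1 to compound 4 (0.20 log units; within the scatter) leaves 4-cyanophenyl and 2-fluorophenyl unresolved within the scatter. No measurement to hand accounts for any of these steps.

The compounds shown do not separate the contribution of the ring nitrogen from that of the chlorine in compound 3, a question that 4-chlorophenyl and unsubstituted pyridin-3-yl would address. Going by these compounds, how an amine or a carboxylic acid on this aryl ring would read also remains open.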